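Phenyl for Bromo: Expecting the Growth Inhibition of Compound 4

This account rests on a few compounds, and the source may have more. Where it says the series, first, only, none or still open, it means among the compounds named here.

Three measured compounds share one core and differ only at the far aromatic ring. Compound 1 `CC(=O)c1ccc(Nc2ccnc(SCC(=O)c3ccc(Br)cc3)n2)cc1` gives 10% in a functional assay on ACHN cells (Homo sapiens) for inhibition, read by sulforhodamine B assay, with a stated time of 48 h, tested at 10 uM (a lower number here means less inhibition of growth, a higher number more inhibition of growth at the concentration tested), the lowest of the three numbers, yet compound 3 `CC(=O)c1ccc(Nc2ccnc(SCC(=O)c3ccc(Cl)cc3)n2)cc1` with 11% and compound 2 `CCOC(=O)c1ccc(Nc2ccnc(SCC(=O)c3ccc([N+](=O)[O-])cc3)n2)cc1` with 15% both lie within the scatter of it. Among the measured compounds shown here, the one measured single change, a number 1 percentage points higher from compound 1 to compound 3 (within the scatter), left the number where it was. Compound 4 `CC(=O)c1ccc(Nc2ccnc(SCC(=O)c3ccc(-c4ccccc4)cc3)n2)cc1` makes a bigger change: phenyl in place of bromo on an aromatic carbon. No measured step adds a ring at this position, so nothing among these compounds points to a shift in this assay. The step of a number 3 percentage points higher from compound 1 to compound 4 (within the scatter) is therefore expected to stay small. Compound 4 is estimated at 13%, with a range from 2% to 30%.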

Compound 4, percent growth inhibition at one concentration: 26%
Compound 4: middle estimate off by 13 percentage points, on the low side; measured number inside the range.
By their numbers in this assay, from the lowest: compounds 1, 3 and 2 (each within the scatter of the next); then compound 4.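

This position can move the number after all. Chloro in place of bromo had stayed within the scatter, but phenyl in place of bromo gives (a number 16 percentage points higher from compound 1 to compound 4 (beyond the scatter)) and phenyl in place of chloro gives (a number 15 percentage points higher from compound 3 to compound 4 (beyond the scatter)), both modest steps beyond the scatter. Nothing available explains why adding this six-membered aromatic ring raises growth inhibition.

Going by these compounds, whether the ring itself matters remains open, since a butyl chain or a cyclohexyl ring at this place could be compared with phenyl. So does the effect of an amine or a carboxylic acid on the added ring.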